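This account rests on a few compounds, and the source may have more. Where it says the series, first, only, none or still open, it means among the compounds named here.

Compound 1 `CC(=O)NCC#CCn1ccnc1` and compound 3 `COC(=O)N(C)C(C)C#CCn1ccnc1` are the two measured starting points of this series; how their cores differ is not broken down here. Both were tested in a functional assay on the whole organism for antagonist activity, with Mus musculus as the target; on this read-out lower numbers stand for an effect already at smaller amounts and higher numbers for an effect only at larger amounts of compound. In this assay compound 1 reaches only a limit of the assay, > 100 mg/kg. Compound 3 likewise reaches only a limit of the assay in this assay, > 100 mg/kg. The shared floor is described by the evidence (the limit of > 100 mg/kg in this assay, at which 2 of the 3 values shown sit).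

From compound 1 the methyl analogue compound 2 `CC(=O)NCC#CCn1cncc1C` was made by the change (methyl in place of hydrogen on an aromatic carbon). In this assay compound 2 gives 66 mg/kg, and the step is an at least 1.5-fold lower number from compound 1 to compound 2 (0.18 log units; that floor lies within the scatter), a movement whose size can only be bounded.

Compound 4 `COC(=O)N(C)C(C)C#CCn1cncc1C` stands to compound 3 as compound 2 stands to compound 1, by the change (methyl in place of hydrogen on an aromatic carbon). The two places are the same kind of change rather than the same: in compound 1 the carbon sits next to the ring atom that bears a group of 8 heavy atoms, in compound 3 next to the ring atom that bears a large group.

Resting on the step of compound 1 to compound 2 an at least 1.5-fold lower number from compound 1 to compound 2 (0.18 log units; that floor lies within the scatter), compound 4 is expected to move by about an at least 1.1-fold lower number from compound 3 to compound 4 (0.04 log units; that floor lies within the scatter) in this assay. The estimate for compound 4 in this assay is 90 mg/kg, with a range from 45 mg/kg to 200 mg/kg.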

Compound 4, dose for half-maximal effect: 6.6 mg/kg
Compound 4: middle estimate off by 14-fold (1.13 log units), on the high side; measured number outside the range, below it.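

In this assay methyl in place of hydrogen on an aromatic carbon gives a large step on the core of compound 3, an at least 15-fold lower number from compound 3 to compound 4 (1.18 log units; beyond the scatter), a movement that lies beyond the scatter, while on the core of compound 1 the floor of the same change stays within it. Both steps point towards a lower number, so nothing shown here goes against the direction of the change on these two cores, but two pairs make no rule for any other core, and the data give no cause for the size of either step. Whether the change is worth more on one core than on the other cannot be said, since each step starts from a limit of the assay and can only be bounded: the same change on two cores in this assay, an at least 1.5-fold lower number (0.18 log units; that floor lies within the scatter) from compound 1 to compound 2 and an at least 15-fold lower number (1.18 log units; beyond the scatter) from compound 3 to compound 4; the limit leaves it open whether they differ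

The compounds shown leave open whether ethyl, a longer chain, or a chlorine atom in the place of this methyl on the core of compound 4 would keep the low number seen in this assay. Also open is how far compound 1 and compound 3 really lie from compound 2 and compound 4, as neither starting point gives more than a limit: the limit of > 100 mg/kg in this assay, at which 2 of the 4 values shown sit.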